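Methoxy Added to a Fully Substituted Ring: Cell Tolerance

A few compounds are considered here, and "the series" means these few. Any claim that something is new, unique, unknown or untested is made for them only; others in the source may bear on it.

Compound 1 `COc1ccc([C@H]2CC(C)(O)[C@@H]3CC[C@@H](C)C[C@H]3O2)c(OC)c1` and compound 2 `COc1ccc([C@H]2CC(C)(O)[C@@H]3CC[C@@H](C)C[C@H]3O2)cc1OC` are built from the same atoms joined differently; the difference between the two cores is not broken down here. In an ADME assay on MDCK cells (Canis lupus familiaris) for cytotoxicity, read by MTT assay, with a stated time of 48 h (a higher number here means that more compound is tolerated, a lower number that less compound is tolerated), compound 1 reaches only a limit, > 937000 nM. Compound 2 likewise reaches only a limit in this assay, > 937000 nM. Compound 3 `COc1cc(OC)c([C@H]2CC(C)(O)[C@@H]3CC[C@@H](C)C[C@H]3O2)c(OC)c1` differs from compound 1 by methoxy in place of hydrogen on an aromatic carbon. In this assay compound 3 gives a number, 856000 nM. The measured step is an at least 1.0-fold lower number from compound 1 to compound 3 (0.03 log units; that floor lies within the scatter), and that step lies within the scatter (the limit of > 937000 nM in this assay, at which 2 of the 3 values shown sit).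

Compound 4 `COc1cc([C@H]2CC(C)(O)[C@@H]3CC[C@@H](C)C[C@H]3O2)cc(OC)c1OC` is not yet measured. It differs from compound 2 by methoxy in place of hydrogen on an aromatic carbon. For the measured compounds named here, this is the same kind of change as the one from compound 1 to compound 3, but the surroundings differ: the new methoxy in compound 4 sits ortho to a methoxy group and meta to a large group and to a methoxy group, whereas in compound 3 it sits ortho to a large group and meta to two methoxy groups. For compound 4 the expected step in this assay is an at least 1.0-fold lower number from compound 2 to compound 4 (0.01 log units; that floor lies within the scatter), resting on the step from compound 1 to compound 3, an at least 1.0-fold lower number from compound 1 to compound 3 (0.03 log units; that floor lies within the scatter), which stayed within the scatter. Compound 4 is therefore estimated at 900000 nM, with a range from 450000 nM to 1500000 nM.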

Compound 4, half-maximal cytotoxic concentration: 405000 nM
For compound 4 the middle estimate is 2.2-fold (0.35 log units) above the measured one, outside the stated range (below it).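

In this assay, methoxy in place of hydrogen on an aromatic carbon gives an at least 2.3-fold lower number from compound 2 to compound 4 (0.36 log units; beyond the scatter), with the new methoxy ortho to a methoxy group, meta to a large group and meta to a methoxy group. This shows that the change can lower the tolerated concentration on one of the two cores by more than the scatter, but it does not show that the change carries over differently from one core to the other, since neither step has a fixed size: the same change on two cores in this assay, an at least 1.0-fold lower number (0.03 log units; that floor lies within the scatter) from compound 1 to compound 3 and an at least 2.3-fold lower number (0.36 log units; beyond the scatter) from compound 2 to compound 4; the limit leaves it open whether they differ Each step starts from a compound that reaches only a limit, so the true size of neither step can be read: the limit of > 937000 nM in this assay, at which 2 of the 4 values shown sit.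

The compounds shown leave open how the step would behave with methoxy at other places on these rings. They also leave open whether a different group on the same aromatic carbon, such as an amine or a carboxylic acid, would give a step of similar size.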